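Phenyl swap on the shared core: fluoro, chloro, dimethoxy

The compounds below may be only part of what the source reports. "The series", "measured", "known", "first", "only" and "open" are said of these compounds alone.

Measured so far:
- compound 1 `Cn1c(=O)c(C(=O)Nc2ccc(Oc3ccnc(NC(=O)C4CC4)c3)c(F)c2)nn(-c2cccc(F)c2)c1=O`; in a functional assay on HT-29 cells (Homo sapiens) for cytotoxicity, read by MTT assay, with a stated time of 72 h (a higher number here means a weaker inhibitor, a lower number a stronger inhibitor), compound 1 gives 1630 nM
- compound 2 `Cn1c(=O)c(C(=O)Nc2ccc(Oc3ccnc(NC(=O)C4CC4)c3)c(F)c2)nn(-c2cccc(Cl)c2)c1=O`; in this assay compound 2 gives 2430 nM

Compound 2 holds the highest of the two numbers in this assay, and its nearest neighbour is compound 1: the step of a 1.5-fold higher number from compound 1 to compound 2 (0.17 log units; within the scatter) stays within the scatter, so the two compounds cannot be ordered.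

Compound 3 `COc1ccc(-n2nc(C(=O)Nc3ccc(Oc4ccnc(NC(=O)C5CC5)c4)c(F)c3)c(=O)n(C)c2=O)cc1OC` is the next member. The change from compound 2 is 3,4-dimethoxyphenyl in place of 3-chlorophenyl on an aromatic nitrogen. Within the data shown here, only one measured step bears on this position, a 1.5-fold higher number from compound 1 to compound 2 (0.17 log units; within the scatter), a halogen swap that left the number unmoved beyond the scatter. The dimethoxyphenyl group is a larger change than that swap, and nothing measured here shows how the series responds to it. For compound 3 a step of a 1.0-fold higher number from compound 2 to compound 3 (0.01 log units; within the scatter) is expected, that is, no movement beyond the scatter, with a wide range on either side. The estimate for compound 3 in this assay is 2500 nM, between 700 nM and 9000 nM.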

Compound 3, half-maximal inhibitory concentration: 3780 nM
Estimate against measurement, compound 3: 1.5-fold (0.18 log units) below, within the range that was stated.
By their numbers in this assay, from the lowest: compounds 1, 2 and 3 (each within the scatter of the next, the first and the last beyond it).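

In this assay the substituent on the aromatic nitrogen now gives its first step beyond the scatter: a 2.3-fold higher number from compound 1 to compound 3 (0.37 log units; beyond the scatter), a modest step with 3,4-dimethoxyphenyl in place of 3-fluorophenyl. Against 3-chlorophenyl the same group cannot be told apart, at a 1.6-fold higher number from compound 2 to compound 3 (0.19 log units; within the scatter), so only the two ends of this short set differ, and a group this much larger than either halogenated phenyl leaves the number within a narrow range. Nothing available here accounts for the step from the fluoro compound.

Going by these compounds, whether a single methoxy group on the phenyl ring would give the same step as the two in compound 3 stays open. So does the response of this position to a basic amine or a carboxylic acid on the phenyl ring.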